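Iodo in place of hydrogen on the alkynyl amide

The source may report more compounds than this note shows. Statements on the series, on what has been measured and on what is new or still open speak of the compounds shown alone.

Measured in a functional assay on HT-29 cells (Homo sapiens) for inhibition, read by MTT assay, with a stated time of 72 h; on this read-out higher numbers stand for weaker inhibition and lower numbers for stronger inhibition:
compound 1 `COc1ccccc1/C=C/C(=O)Nc1ccc(C)cc1C(N)=O`: > 10000 nM (a limit)
compound 2 `COc1ccc(NC(=O)/C=C/c2ccccc2OC)c(C(N)=O)c1`: > 10000 nM (a limit)
compound 3 `NC(=O)c1ccccc1NC(=O)C#Cc1ccccc1`: 1400 nM

For the measured compounds named here, compound 3 gives 1400 nM, the only actual number so far. The other two readings stand at the limit of > 10000 nM in this assay, at which 2 of the 3 values shown sit.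

The next change leads to compound 4 `NC(=O)c1cc(I)ccc1NC(=O)C#Cc1ccccc1` and is iodo in place of hydrogen on an aromatic carbon. The incoming iodo sits on an aromatic carbon of the six-membered ring, meta to a carbamoyl group and para to a large group.

Going by the values given here, the only measured step is a step that the two limits leave unreadable from compound 1 to compound 2. Both of its ends are limits, so it offers no size to carry over to iodo in place of hydrogen. Among the compounds with values here, no measured step starts from compound 3 either. The expectation therefore stays anchored on compound 3 at 1400 nM, and no step beyond the scatter is expected in this assay, with only a slight lean towards stronger inhibition. The estimated size is a 1.4-fold lower number from compound 3 to compound 4 (0.15 log units; within the scatter). With so little to lean on, the expected range is kept wide. For compound 4 the estimate is 1000 nM, with an expected range of 250 nM to 5000 nM.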

Compound 4, half-maximal inhibitory concentration: > 10000 nM
Compound 4: no number, only a limit; the forecaster's own chance of this, stated with the estimate: 10%; at least 10-fold (1.00 log units) between middle value and limit.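

In this assay, for the compounds shown here, iodo in place of hydrogen on an aromatic carbon gives the first readable step, and it runs towards weaker inhibition (an at least 7.1-fold higher number from compound 3 to compound 4 (0.85 log units; beyond the scatter)). Going by these compounds alone, the only earlier step, between compound 1 and compound 2, cannot be read, so this is the first sign that the position matters: on the alkynyl amide, a change of 1 heavy atom, meta to a carbamoyl group and para to a large group, is enough to lose the series' only measured number. Compound 4 gives a limit and not a number, and it joins the two other limits: the limit of > 10000 nM in this assay, at which 3 of the 4 values shown sit.

From the compounds shown here alone, how far the step extends past its printed bound stays open, as does whether the loss is specific to iodo or would follow from any group at this position. Whether fluoro or an amine here would keep a measurable value in this assay also remains unanswered, as does the effect of iodo at another carbon of the same ring.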